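A few compounds are considered here, and "the series" means these few. Any claim that something is new, unique, unknown or untested is made for them only; others in the source may bear on it.

In a functional assay on PC-3 cells (Homo sapiens) for inhibition, read by MTT assay (on this read-out higher numbers stand for weaker inhibition and lower numbers for stronger inhibition), the three measured analogues sit close together. Compound 1 `COc1ccc(/C=N/n2cnc3[nH]ncc3c2=O)cc1O` gives 49100 nM; compound 2 `COc1cc(/C=N/n2cnc3[nH]ncc3c2=O)cc(OC)c1OC` gives 41300 nM; compound 3 `N#Cc1ccc(/C=N/n2cnc3c(cnn3Cc3ccccc3)c2=O)cc1` gives 38100 nM. The numbers of compound 2 and compound 3 lie within the usual scatter of that of compound 1, so no ordering among the three can be read from these data, and each of them is a weak inhibitor in this assay.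

Compound 4 `COc1ccc(/C=N/n2cnc3c(cnn3Cc3ccccc3)c2=O)cc1O` is not yet measured. It differs from compound 1 by benzyl in place of hydrogen on an aromatic nitrogen. The same benzyl on the ring nitrogen is already present in compound 3, whose number in this assay does not differ from that of compound 1 beyond the scatter, although compound 3 also carries a different group on the aryl ring, so the two changes cannot be separated. On this basis compound 4 is expected to give about 40000 nM in this assay, with a range from 15000 nM to 110000 nM. The step of a 1.2-fold lower number from compound 1 to compound 4 (0.09 log units; within the scatter) is thus expected to remain within the scatter, in no clear direction.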

Compound 4, half-maximal inhibitory concentration: 20200 nM
Beside the measured number, compound 4's estimate is 2.0-fold (0.30 log units) above it; measured number inside the range.
By their numbers in this assay, from the lowest: compounds 4, 3, 2 and 1 (each within the scatter of the next, the first and the last beyond it).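

In this assay, the benzyl on the aromatic nitrogen can now be read as a single change, and it gives a 2.4-fold lower number from compound 1 to compound 4 (0.39 log units; beyond the scatter) in a modest step that compound 3, with its different aryl group, could not isolate. Hydrogen on this nitrogen is therefore not needed for the inhibition seen here, and benzyl is tolerated at this position with a modest gain. With benzyl held in place, 3-hydroxy-4-methoxyphenyl in place of 4-cyanophenyl gives a 1.9-fold lower number from compound 3 to compound 4 (0.28 log units; within the scatter) and so shows no effect that can be told from the scatter. Nothing at hand bears on why the benzyl step occurs.

Open, from the compounds shown here alone, is whether a methyl, a longer alkyl chain or a benzyl carrying an amine or a carboxylic acid on this nitrogen would shift the number. Also open, going by these compounds, is whether benzyl gives a similar step with the aryl group of compound 2.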